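The compounds below may be only part of what the source reports. "The series", "measured", "known", "first", "only" and "open" are said of these compounds alone.

Measured so far:
compound 1 `CCc1ccc(OCC(=O)Nc2ccc(OCC(=O)O)c(F)c2)cc1`: 14.6%
compound 2 `COc1ccc(OCC(=O)Nc2ccc(OCC(=O)O)c(F)c2)cc1`: 5.73%

In a functional assay on CHO cells for agonist activity at Free fatty acid receptor 1 (Homo sapiens), read by FLIPR, tested at 100 nM (a higher number here means a stronger effect of the compound at the concentration tested, a lower number a weaker effect), compound 2 gives the lower of the two numbers, yet the step of a number 8.9 percentage points lower from compound 1 to compound 2 (within the scatter) is within the scatter, so the two compounds cannot be separated. Compound 3 `O=C(O)COc1ccc(NC(=O)COc2ccc(OC(F)(F)F)cc2)cc1F` differs from compound 2 by trifluoromethyl in place of methyl on an oxygen on an aromatic ring. Within the data shown here, the only measured step concerns a different group and was itself within the scatter; no measured step bears directly on this change. Compound 3 is therefore expected to move little, a number 4.3 percentage points higher from compound 2 to compound 3 (within the scatter). Compound 3 is estimated at 10%, likely between 0% and 25%.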

Compound 3, a percentage reported as activity, at one concentration (the size of the read-out at that concentration, not a potency) in the Free fatty acid receptor 1 assay: 6.45%
For compound 3 the middle estimate is 3.6 percentage points above the measured one, within the range that was stated.
By their numbers in the Free fatty acid receptor 1 assay, from the lowest: compounds 2, 3 and 1 (each within the scatter of the next).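

In the Free fatty acid receptor 1 assay compound 3 gives 6.45% and the change on the oxygen gives a number 0.7 percentage points higher from compound 2 to compound 3 (within the scatter) and, measured against the ethyl group, trifluoromethoxy gives a number 8.2 percentage points lower from compound 1 to compound 3 (within the scatter) with the shared core unchanged. Trifluoromethoxy therefore joins ethyl and methoxy as a third group on this aromatic carbon that cannot be separated from the others at the concentration tested, and adding three fluorine atoms to the methoxy group produces no readable change. Among these compounds, in a physicochemical assay for lipophilicity, using the shake flask method, at pH 7.4 (on this read-out lower numbers stand for lower lipophilicity and higher numbers for higher lipophilicity), compound 2 is given as "not determined" (no result reported) and compound 3 as "not determined" (no result reported) so no step between them can be read there. No evidence bearing on this result is available. As far as these compounds go, whether an amine or a longer chain on this aromatic carbon would give a number beyond the scatter remains open. So does whether these three compounds would separate in a full potency measurement.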